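Hydrazone thiazole series: cyano to nitro step

A few compounds are considered here, and "the series" means these few. Any claim that something is new, unique, unknown or untested is made for them only; others in the source may bear on it.

Measured so far:
- compound 1 `N#Cc1ccc(-c2csc(N/N=C\c3ccco3)n2)cc1`: 40%
- compound 2 `N#Cc1ccc(-c2csc(N/N=C\c3c[nH]c4ccccc34)n2)cc1`: "not active" (no number reported)

In an in vitro assay on BTI-TN-5B1-4 cells for inhibition of Amine oxidase [flavin-containing] A (Homo sapiens), read by Amplex Red, with a stated time of 15 min, tested at 100 uM (a lower number here means less inhibition, a higher number more inhibition at the concentration tested (going by the name of the read-out)), compound 1 gives 40%. Compound 2 was recorded in this assay as "not active" (no number reported), so no single number stands for it. Compound 3 `O=[N+]([O-])c1ccc(-c2csc(N/N=C\c3c[nH]c4ccccc34)n2)cc1` differs from compound 2 in one place: nitro in place of cyano on an aromatic carbon. Among the compounds with values here, with compound 2 reported without a number and no measured step to guide the size of the change, the expectation is a shift of no more than the usual scatter, most likely staying low. Compound 3 is estimated at 15% in this assay, expected to fall between 0% and 40%.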

Compound 3, a percentage reported as inhibition, at one concentration (the size of the read-out at that concentration, not a potency): "not active" (no number reported)
Compound 3: no number reported; the estimate stays without a comparison.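

Compound 2 and compound 3 both stand without a number in this assay and so no step can be read between them. No supporting data bear on this result. The compounds shown leave open whether nitro in place of cyano changes inhibition at all.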